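This account rests on a few compounds, and the source may have more. Where it says the series, first, only, none or still open, it means among the compounds named here.

Compound 1 `N#Cc1ccc(C(O)(c2ccc(C(F)(F)F)cc2)c2cccnc2)cc1` and compound 2 `N#Cc1ccc(C(O)(c2ccc(C(F)(F)F)cc2)c2cccnc2)c(F)c1` share one core, while compound 3 `NC(=O)c1cccc(C(O)(c2ccc(Cl)cc2)c2cccnc2)c1` has another; the difference between the two cores is not broken down here. In an ADME assay on L6 cells (Rattus norvegicus) for cytotoxicity, read by resazurin assay, with a stated time of 72 h (on this read-out lower numbers stand for stronger inhibition and higher numbers for weaker inhibition), compound 1 gives 76500 nM. Compound 2 gives 56100 nM in this assay, so the change fluoro in place of hydrogen on an aromatic carbon made a 1.4-fold lower number from compound 1 to compound 2 (0.13 log units; within the scatter). For compound 3, this assay reports only a limit of > 100000 nM, a case of the limit of > 100000 nM in this assay, at which 1 of the 3 values shown sits. Compound 4 `NC(=O)c1cccc(C(O)(c2cccnc2)c2ccc(Cl)cc2F)c1` carries the same kind of change, (fluoro in place of hydrogen on an aromatic carbon); around the place it is meta to a chloro group rather than meta to a cyano group. In this assay the step is expected to be a number no higher from compound 3 to compound 4 (the limit leaves the size open), resting on a 1.4-fold lower number from compound 1 to compound 2 (0.13 log units; within the scatter). Compound 4 is thus estimated at 100000 nM in this assay, with an expected range from 50000 nM to 200000 nM.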

Compound 4, half-maximal inhibitory concentration in the L6 assay: > 100000 nM
Compound 4 was reported as a limit; the forecaster's own chance of this, stated with the estimate: 60%; the middle value lies on the limit itself.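

In the L6 assay compound 3 is reported as a limit, > 100000 nM. In the L6 assay compound 4 is also reported as a limit, > 100000 nM. No step between them can be read: the limit of > 100000 nM in the L6 assay, at which 2 of the 4 values shown sit.

The compounds shown leave open whether fluoro in place of hydrogen on an aromatic carbon changes the number for the core of compound 3 in the L6 assay.

In a physicochemical assay for solubility, read by nephelometry, measured as kinetic solubility, at pH 6.5 (a lower number here means a less soluble compound, a higher number a more soluble compound), compound 3 gives 50 ug/mL and compound 4 gives 50 ug/mL. In the physicochemical assay fluoro in place of hydrogen on an aromatic carbon gives no change at the digits printed from compound 3 to compound 4 (within the scatter).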